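This account rests on a few compounds, and the source may have more. Where it says the series, first, only, none or still open, it means among the compounds named here.

Measured in a functional assay on ECa-109 cells (Homo sapiens) for antiproliferative activity, read by MTT assay, with a stated time of 48 h; on this read-out lower numbers stand for stronger inhibition and higher numbers for weaker inhibition:
- compound 1 `Cn1cc(C2=C(c3nn(CCCn4cncn4)c4ncccc34)C(=O)NC2=O)c2ccccc21`: > 100000 nM (a limit)
- compound 2 `Cn1cc(C2=C(c3nn(CCCn4ccnc4)c4ncccc34)C(=O)NC2=O)c2ccccc21`: > 100000 nM (a limit)
- compound 3 `Cn1cc(C2=C(c3nn(CCCN4CCCCC4)c4ncccc34)C(=O)NC2=O)c2ccccc21`: 42300 nM

Compound 3 alone gives an actual number, 42300 nM. Compounds 1 and 2 instead sit at the limit of > 100000 nM in this assay, at which 2 of the 3 values shown sit.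

Compound 4 `Cn1cc(C2=C(c3nn(CCCO)c4ncccc34)C(=O)NC2=O)c2ccccc21` carries hydroxy in place of piperidin-1-yl on a saturated chain carbon, three bonds along the chain from an aromatic nitrogen.

Among the measured compounds shown here, two measured steps bear on this group: an at least 2.3-fold lower number from compound 1 to compound 3 (0.37 log units; beyond the scatter) and an at least 2.3-fold lower number from compound 2 to compound 3 (0.37 log units; beyond the scatter). Both arrive at piperidin-1-yl from other groups, and neither involves hydroxy, so the guide is indirect. Losing piperidin-1-yl is therefore expected to give a modest move towards weaker inhibition, and a limit is quite possible. The expected step is a 1.8-fold higher number from compound 3 to compound 4 (0.25 log units; within the scatter). For compound 4 the estimate is 75000 nM, with an expected range of 25000 nM to 200000 nM.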

Compound 4, half-maximal inhibitory concentration: > 100000 nM
Compound 4: a limit, no number; the forecaster's own chance of this, stated with the estimate: 45%; at least 1.3-fold (0.12 log units) between middle value and limit.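

In this assay, putting hydroxy in place of piperidin-1-yl gives an at least 2.3-fold higher number from compound 3 to compound 4 (0.37 log units; beyond the scatter), so a chain end with no ring at all does not keep the activity of compound 3. Among the chain ends shown, piperidin-1-yl remains the only one with a readable number. Compound 4 gives a limit, not a number: the limit of > 100000 nM in this assay, at which 3 of the 4 values shown sit.

The steps from compound 1 and from compound 2 to compound 4 cannot be read, as both ends of each are limits. As far as these compounds go, whether a simple amine such as dimethylamino, or a morpholin-4-yl group, would match piperidin-1-yl at this chain end remains open.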